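The compounds below may be only part of what the source reports. "The series", "measured", "known", "first", "only" and "open" are said of these compounds alone.

In a functional assay on U-251 cells (Homo sapiens) for inhibition, read by MTT assay, with a stated time of 2 days (on this read-out higher numbers stand for lower toxicity in this test and lower numbers for higher toxicity in this test), compound 1 (`Nc1ccccc1NC(=O)CCCNCC(=O)Nc1cccc([N+](=O)[O-])c1`) gives > 100000 nM, which is a limit of the assay. Compound 2 (`Nc1ccccc1NC(=O)c1ccc(NCC(=O)Nc2ccc([N+](=O)[O-])cc2)cc1`) gives > 100000 nM, also a limit. Compound 3 (`Nc1ccccc1NC(=O)c1ccc(NCC(=O)Nc2cccc([N+](=O)[O-])c2)cc1`) gives > 100000 nM, again a limit and not a number. Compound 3 therefore stands with the other two, and the record so far is the limit of > 100000 nM in this assay, at which 3 of the 3 values shown sit.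

Compound 4 (`COc1ccc(NC(=O)CNc2ccc(C(=O)Nc3ccccc3N)cc2)cc1`) carries 4-methoxyphenyl in place of 3-nitrophenyl on an amide-type nitrogen. Among the measured compounds shown here, the one measured step at this place is a step that the two limits leave unreadable from compound 2 to compound 3, so it offers no size to carry over. For the measured compounds named here, no measured compound carries the 4-methoxyphenyl group. No shift beyond the scatter is therefore expected in this assay, and no direction can be given. The expectation rests on compound 3, whose > 100000 nM is a limit. The estimated change is a number no higher from compound 3 to compound 4 (the limit leaves the size open). For compound 4 the estimated value is 100000 nM, with an expected range from 40000 nM to 200000 nM.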

Compound 4, concentration lethal to 50% of the cells: > 100000 nM
Compound 4: only a limit was reported; the forecaster's own chance of this, stated with the estimate: 75%; the middle value lies on the limit itself.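

In this assay compound 4 gives > 100000 nM, which is a limit of the assay. Among the compounds shown here, its steps from compound 2 and from compound 3 cannot be read, so no new step emerges. The compounds shown leave open whether any change among them alters toxicity in this test, since the record stands at: the limit of > 100000 nM in this assay, at which 4 of the 4 values shown sit.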